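The source may hold more compounds than are shown below. What is called first, only, known or untested is meant among the compounds shown, and "the series" means these compounds.

Working notes on the series in a functional assay (strain AB) with Danio rerio as the target, read by microscopy, with a stated time of 1 h; a higher number here means that more compound is needed for the effect, a lower number that less compound is needed.

Compound 2 `CCN1CCc2c(sc(NC(=O)c3ccccc3)c2C(N)=O)C1` reaches only the limit of the assay: in this assay compound 2 gives > 25000 nM, a limit rather than a number, as marked by the limit of > 25000 nM in this assay, at which 1 of the 2 values shown sits. Compound 1 `NC(=O)c1c(NC(=O)Nc2ccc(Cl)cc2)sc2c1CCN(CC1CCCC1)C2` shares the core and carries an amino-linked aryl ring, rather than a phenyl, on its carbonyl carbon; in this assay compound 1 gives 1830 nM.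

Compound 3 `CCN1CCc2c(sc(NC(=O)Nc3cccc(C)c3)c2C(N)=O)C1` has not been measured. Its change from compound 2 is (3-methylphenyl)amino in place of phenyl on a carbonyl carbon. Among the compounds with values here, no measured pair isolates this change, so the expectation rests on compound 2 sitting at the limit of the assay. It rests as well on compound 1, which in this assay gives 1830 nM. A step toward lower concentration, beyond the scatter, is expected; the estimated step is an at least 3.1-fold lower number from compound 2 to compound 3 (0.49 log units; beyond the scatter). For compound 3 the expected value in this assay is 8000 nM, with a range from 2500 nM to 25000 nM.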

Compound 3, half-maximal effective concentration: 13000 nM
Estimate against measurement, compound 3: 1.6-fold (0.21 log units) below; low and high end bracket the measured number.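

Within the data shown here, on the carbonyl carbon whose other neighbour is the amide-type nitrogen, compounds 2 and 3 give the first comparison that differs in one place, and in this assay the reading is an at least 1.9-fold lower number from compound 2 to compound 3 (0.28 log units; that floor lies within the scatter). The value of compound 2 is a limit and not a number: the limit of > 25000 nM in this assay, at which 1 of the 3 values shown sits.

With (3-methylphenyl)amino in place of phenyl, compound 3 gives 13000 nM, a number inside the range of this assay, so this position on the ethyl-bearing compounds can now be read as a value rather than a limit.

The single change brings in both the amino nitrogen and the methyl, and no pair shown separates the two. From the compounds shown here alone, how a methoxy group in place of that methyl, or a cyclohexyl ring in place of the whole aryl ring, would read remains open.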